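Methoxy to ethoxy on the pyrrolidine carbamate

This account rests on a few compounds, and the source may have more. Where it says the series, first, only, none or still open, it means among the compounds named here.

Measured in a functional assay on the whole organism for antagonist activity, with Mus musculus as the target; a higher number here means that more compound is needed for the effect, a lower number that less compound is needed:
- compound 1 `COC(=O)N(C)C(C)C#CCN1CCCC1`: > 100 mg/kg (a limit)
- compound 2 `COC(=O)N(C)C(C)C#CCn1ccnc1`: > 100 mg/kg (a limit)

Compound 1 has no number in this assay, only the limit > 100 mg/kg. Compound 2 likewise has only a limit, > 100 mg/kg. All the data so far come down to the limit of > 100 mg/kg in this assay, at which 2 of the 2 values shown sit.

Compound 3 `CCOC(=O)N(C)C(C)C#CCN1CCCC1` keeps the core of compound 1 and changes methoxycarbonyl to ethoxycarbonyl: methyl in place of hydrogen on a saturated chain carbon bound to an oxygen next to a carbonyl group. In other words, it has methyl in place of hydrogen on a saturated chain carbon bound to an oxygen next to a carbonyl group.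

Within the data shown here, only one measured step is available, a step that the two limits leave unreadable from compound 1 to compound 2. It lies at a different place in the molecule and gives no size to carry over, so no step beyond the scatter can be argued for in this assay and no direction is expected. The expected outcome is a step that the limit leaves unreadable from compound 1 to compound 3, and a report as a limit is the more likely result. For compound 3 the estimated value is 130 mg/kg, with an expected range from 50 mg/kg to 350 mg/kg.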

Compound 3, dose for half-maximal effect: 97 mg/kg
Compound 3: the middle estimate sits 1.3-fold (0.13 log units) above what was measured, within the range that was stated.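

Methyl in place of hydrogen on a saturated chain carbon bound to an oxygen next to a carbonyl group brings the series to a readable number in this assay: compound 3 gives 97 mg/kg. Set against the limit of compound 1, the change reads as an at least 1.0-fold lower number from compound 1 to compound 3 (0.01 log units; that floor lies within the scatter), so only a floor is available and its true size cannot be stated. This position therefore accepts ethoxycarbonyl in place of methoxycarbonyl with the pyrrolidin-1-yl group kept, and compound 3 is the only one of the three compounds with a number, the others remaining at a limit: the limit of > 100 mg/kg in this assay, at which 2 of the 3 values shown sit.

Going by these compounds, the step between the two compounds that both sit at the limit cannot be read, so the effect of 1H-imidazol-1-yl in place of pyrrolidin-1-yl remains unknown, and it is also open whether that exchange would give a readable number on the ethoxycarbonyl compound. Equally open, on these data alone, is whether a longer chain such as propoxycarbonyl, or a branched group such as isopropoxycarbonyl, would lower the dose in this assay beyond the scatter relative to compound 3.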